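The source may report more compounds than this note shows. Statements on the series, on what has been measured and on what is new or still open speak of the compounds shown alone.

Of the compounds shown here, three have been measured in a functional assay on C6 cells (Rattus norvegicus) for cytotoxicity, read by MTT assay, with a stated time of 24 h, tested at 100 ug/mL; on this read-out lower numbers stand for a stronger effect and higher numbers for a weaker effect at the one concentration tested. Compound 1 `Cc1ccc(-c2cs/c(=N/NC(=O)CSc3nnnn3-c3ccccc3)n2-c2ccccc2)cc1` gives 28.5%. Compound 2 `O=C(CSc1nnnn1-c1ccccc1)N/N=c1/scc(-c2ccc(Cl)cc2)n1-c1ccccc1` differs from compound 1 by a single change; in this assay compound 2 gives 54.3%. For the measured compounds named here, the step of a number 25.8 percentage points higher from compound 1 to compound 2 (beyond the scatter) is the only one between two measured compounds that differ in one place. Compound 3 `Cn1nnnc1SCC(=O)N/N=c1/scc(-c2ccc(C#N)cc2)n1-c1ccccc1` gives 30.9%, which places it second highest of the three numbers: its value lies within the scatter of the value of compound 1, while the value of compound 2 stands beyond the scatter, higher.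

Compound 4 `N#Cc1ccc(-c2cs/c(=N/NC(=O)CSc3nnnn3-c3ccccc3)n2-c2ccccc2)cc1` has not yet been measured. It differs from compound 3 as follows: phenyl in place of methyl on an aromatic nitrogen. Going by the values given here, no measured step bears directly on this change. The step from compound 1 to compound 2 sits in another place, on an aromatic carbon of the aryl ring, and says nothing about a change on the tetrazole nitrogen. What the numbers do show is that compound 1 and compound 2 both carry the 1-phenyl-1H-tetrazol-5-yl group that enters in compound 4, and that compound 3, with the 1-methyl-1H-tetrazol-5-yl group, lies within the scatter of compound 1.

Compound 4 is therefore expected to show a step of about a number 0.1 percentage points higher from compound 3 to compound 4 (within the scatter) in this assay, that is, none beyond the scatter. For compound 4 the estimate is 31%, with a range from 18% to 46%.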

Compound 4, a percentage reported as activity, at one concentration (the size of the read-out at that concentration, not a potency): 59.8%
Beside the measured number, compound 4's estimate is 28.8 percentage points below it, outside the stated range (above it).
By their numbers in this assay, from the lowest: compounds 1 and 3 (each within the scatter of the next); then compounds 2 and 4 (each within the scatter of the next).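

In this assay, for the compounds shown here, the change from 1-methyl-1H-tetrazol-5-yl to 1-phenyl-1H-tetrazol-5-yl gives a number 28.9 percentage points higher from compound 3 to compound 4 (beyond the scatter), the first direct reading at this aromatic nitrogen, and it shows that with cyano on the aromatic carbon, the methyl group goes with the stronger effect and the phenyl group with the weaker one. With the 1-phenyl-1H-tetrazol-5-yl group held constant, compound 4 also shows that the aromatic carbon responds unevenly: cyano in place of chloro gives a number 5.5 percentage points higher from compound 2 to compound 4 (within the scatter), whereas cyano in place of methyl gives a number 31.3 percentage points higher from compound 1 to compound 4 (beyond the scatter), so cyano and chloro cannot be told apart here and both separate from methyl. Nothing available accounts for either the nitrogen step or the carbon steps.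

Going by these compounds, whether the step from methyl to phenyl on the nitrogen keeps its size with chloro or methyl on the aromatic carbon remains open. Also open, on these data alone, is how an ethyl or benzyl group would behave on that nitrogen, and how an amine or a carboxylic acid would behave on the aromatic carbon.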